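Removing the amine-bearing group from compound 3

This account rests on a few compounds, and the source may have more. Where it says the series, first, only, none or still open, it means among the compounds named here.

Measured in an ADME assay on A549 cells (Homo sapiens) for cytotoxicity, with a stated time of 72 h; on this read-out higher numbers stand for weaker inhibition and lower numbers for stronger inhibition:
- Compound 1 `COc1cc(NC(C)CCCN2C(=O)[C@@H](C)N(C(=O)CN)C2(C)C)c2ncccc2c1`: > 100000 nM (a limit of the assay, not a number)
- Compound 2 `COc1cc(NC(C)CCCN2C(=O)CN(C(=O)[C@H](N)CCSC)C2(C)C)c2ncccc2c1`: 7900 nM
- Compound 3 `COc1cc(NC(C)CCCN2C(=O)CN(C(=O)[C@@H](C)N)C2(C)C)c2ncccc2c1`: 7800 nM

Among the measured compounds shown here, compound 3 stands level with compound 2, and these two hold the only true numbers so far. The step is a 1.0-fold lower number from compound 2 to compound 3 (0.01 log units; within the scatter).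

The next structure is compound 4 `COc1cc(NC(C)CCCN2C(=O)CN(C(C)=O)C2(C)C)c2ncccc2c1`. It keeps the shared core and has methyl in place of 1-aminoethyl on a carbonyl carbon, which turns (1-aminoethyl)carbonyl into acetyl.

For the measured compounds named here, only one measured step bears on this change, and only loosely. That step, a 1.0-fold lower number from compound 2 to compound 3 (0.01 log units; within the scatter), places hydrogen where (methylsulfanyl)methyl stood on a saturated chain carbon, but it leaves the amine in place. Going by the values given here, no measured step removes the amine, so its effect has no direct measure here.

Compound 1 gives > 100000 nM, which is a limit.

The numbers therefore offer no firm size for this step, and the expectation is only a modest move toward weaker inhibition in this assay, with wide uncertainty. The expected step is a 1.8-fold higher number from compound 3 to compound 4 (0.25 log units; within the scatter). For compound 4 the estimated value is 14000 nM. The estimated range for compound 4 runs from 4000 nM to 60000 nM.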

Compound 4, half-maximal inhibitory concentration: > 100000 nM
Compound 4 ended at the assay's limit (the forecaster's own chance of this, stated with the estimate: 15%); middle value at least 7.1-fold (0.85 log units) from the limit.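

Compound 2 and compound 3 carry different amine-bearing groups on the carbonyl carbon, and their numbers in this assay lie within the scatter of each other, so they did not show what happens when such a group is lost altogether. Among the compounds shown here, compound 4 shows this for the first time: replacing 1-aminoethyl with methyl gives an at least 12-fold higher number from compound 3 to compound 4 (1.10 log units; beyond the scatter), a clear shift toward weaker inhibition. Replacing 1-amino-3-(methylsulfanyl)propyl with methyl at the same place points the same way, with an at least 12-fold higher number from compound 2 to compound 4 (1.10 log units; beyond the scatter), but the value of compound 4 is a limit, so each step gives only a minimum size: the limit of > 100000 nM in this assay, at which 2 of the 4 values shown sit.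

The compounds shown cannot separate the loss of the amine from the loss of the carbon chain that carries it, and an ethyl group on the carbonyl carbon would keep the chain carbons without the amine. From the compounds shown here alone, it also remains open whether another group carrying a heteroatom, such as 1-hydroxyethyl, or a carboxylic acid at this place would keep the number of compound 3 or move it toward that of compound 4.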